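Anilino Variants That All Sit Near the Assay Ceiling

The source may hold more compounds than are shown below. What is called first, only, known or untested is meant among the compounds shown, and "the series" means these compounds.

Compound 1 `Fc1cccc(-c2nc(Nc3ccccc3)c3cc(F)ccc3n2)c1`: in a functional assay on MCF7 cells (Homo sapiens) for cytotoxicity, read by MTT assay, with a stated time of 48 h (on this read-out higher numbers stand for weaker inhibition and lower numbers for stronger inhibition), compound 1 gives 49700 nM.
Compound 2 `COc1ccc(Nc2nc(-c3cccc(F)c3)nc3ccc(F)cc23)cc1`: in this assay compound 2 gives 48400 nM.
Compound 3 `Oc1cccc(Nc2nc(-c3cccc(F)c3)nc3ccc(F)cc23)c1`: in this assay compound 3 gives > 50000 nM, which is a limit of the assay and not a number.

Compound 3 therefore stands at the weak end of the numbers shown; its value is only a limit, (the limit of > 50000 nM in this assay, at which 1 of the 3 values shown sits). Among the measured steps, from compound 1 to compound 2 there was a 1.0-fold lower number from compound 1 to compound 2 (0.01 log units; within the scatter). From compound 1 to compound 3 there was a number no lower from compound 1 to compound 3 (the limit leaves the size open). From compound 2 to compound 3 there was an at least 1.0-fold higher number from compound 2 to compound 3 (0.01 log units; that floor lies within the scatter). None of these changes at the anilino nitrogen moved the read-out beyond the scatter.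

Compound 4 `Nc1ccccc1Nc1nc(-c2cccc(F)c2)nc2ccc(F)cc12` differs from compound 3 in one place: 2-aminophenyl in place of 3-hydroxyphenyl on a nitrogen on an aromatic ring. Among the measured compounds shown here, the steps that bear on this change are the two earlier exchanges at the same nitrogen, and both stayed within the scatter. The expectation for compound 4 in this assay is therefore no step beyond the scatter, that is a number no higher from compound 3 to compound 4 (the limit leaves the size open). Compound 4 is expected to give about 50000 nM, within a range from 25000 nM to 100000 nM, with a fair chance that only a limit is reported again.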

Compound 4, half-maximal inhibitory concentration: > 50000 nM
Compound 4 gave a limit, no number; the forecaster's own chance of this, stated with the estimate: 50%; the middle value sits exactly at the limit.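

In this assay compound 4 gives > 50000 nM, which is a limit of the assay and not a number. Among the compounds shown here, the steps that can be read are an at least 1.0-fold higher number from compound 2 to compound 4 (0.01 log units; that floor lies within the scatter) and a number no lower from compound 1 to compound 4 (the limit leaves the size open), and the one remaining step cannot be read. The exchange thus extends the earlier picture from hydrogen, methoxy and hydroxy to an amino group on the anilino ring: even with 2-aminophenyl on this nitrogen, no step beyond the scatter appears, and the series now gathers at the end of the assay's range: the limit of > 50000 nM in this assay, at which 2 of the 4 values shown sit.

As far as these compounds go, how far compound 3 and compound 4 lie past the limit stays open, so 2-aminophenyl and 3-hydroxyphenyl cannot be ranked against each other, and neither can be set in order with the unsubstituted phenyl of compound 1. Also open, from the compounds shown here alone, is whether a different group on this nitrogen, such as a benzyl group or a phenyl ring carrying a carboxylic acid, or a change in the shared core, would bring the read-out clear of the limit.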